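Ethyl to Methyl on the Shared Core

The source may hold more compounds than are shown below. What is called first, only, known or untested is meant among the compounds shown, and "the series" means these compounds.

Compound 1 `Cc1cc2c(cc1C(=O)N=C(N)N)S(=O)(=O)C(C)(C)CC2C`: 1100 nM
Compound 2 `Cc1cc2c(cc1C(=O)N=C(N)N)S(=O)(=O)CCCC2`: 274 nM
Compound 3 `CCC1(O)CS(=O)(=O)c2cc(C(=O)N=C(N)N)c(C)cc21`: 77 nM

All three values come from a functional assay for inhibition, with Homo sapiens as the target; a higher number here means a weaker inhibitor, a lower number a stronger inhibitor. Compound 3 has the lowest number of the three, and both compound 2 and compound 1 lie beyond the scatter above it. Compound 4 `Cc1cc2c(cc1C(=O)N=C(N)N)S(=O)(=O)CC2(C)O` has not yet been measured. It differs from compound 3 by hydrogen in place of methyl on a saturated chain carbon bound to a saturated ring carbon, with hydrogen in place of methyl on a saturated chain carbon bound to a saturated ring carbon, so that ethyl becomes methyl. For the measured compounds named here, no measured pair shows this change, so the data offer no direct guide to its size. The expected change is a 1.6-fold higher number from compound 3 to compound 4 (0.19 log units; within the scatter), a small move toward a higher number that stays within the scatter. For compound 4 the estimated value is 120 nM, with an expected range of 40 nM to 350 nM.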

Compound 4, half-maximal inhibitory concentration: 115 nM
Estimate against measurement, compound 4: 1.0-fold (0.02 log units) above, and the stated range covers the measured number.
By their numbers in this assay, from the lowest: compounds 3 and 4 (each within the scatter of the next); then compound 2; then compound 1.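

For the compounds shown here, the pair gives the first direct reading of this change: a 1.5-fold higher number from compound 3 to compound 4 (0.17 log units; within the scatter) is the step in this assay for hydrogen in place of methyl on a saturated chain carbon bound to a saturated ring carbon. Ethyl and methyl at this place therefore cannot be told apart by this read-out. No measured evidence bears on this result. The compounds shown leave open how a longer chain such as propyl would read in this assay and whether an amine or a carboxylic acid on that chain would stay within the same scatter.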